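Cyano in place of ethyl on compound 2

The source may hold more compounds than are shown below. What is called first, only, known or untested is meant among the compounds shown, and "the series" means these compounds.

Compound 1 `COc1cccc([C@@H](C)NC(=O)c2ccc(-c3cn[nH]c3)c(C)c2)c1` with 74% remaining
Compound 2 `CCc1cc(C(=O)N[C@H](C)c2cccc(OC)c2)ccc1-c1cn[nH]c1` with 38% remaining

In an ADME assay on microsomes from liver (Homo sapiens) for metabolic stability, with a stated time of 10 min, tested at 0.5 uM (on this read-out higher numbers stand for a more stable compound and lower numbers for a less stable compound), compound 2 stands lowest of the two measured compounds, at 38% so far. Compound 3 `COc1cccc([C@@H](C)NC(=O)c2ccc(-c3cn[nH]c3)c(C#N)c2)c1` is unmeasured and differs from it by cyano in place of ethyl on an aromatic carbon in one place: cyano in place of ethyl on an aromatic carbon, ortho to a 1H-pyrazol-4-yl group. Within the data shown here, only one measured step bears on this, a number 36 percentage points lower from compound 1 to compound 2 (beyond the scatter) for methyl in place of hydrogen on a saturated chain carbon bound to an aromatic carbon. That step is large, and it concerns the same carbon substituent that now leaves. Among the measured compounds shown here, no cyano compound has been measured, so the transfer is uncertain. A large upward step of similar size is expected, with ethyl gone. The expected change is a number 32 percentage points higher from compound 2 to compound 3 (beyond the scatter) as an estimate resting on that single step. The estimated value for compound 3 is 70% with a range from 48% to 88% expected.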

Compound 3, percent of the compound remaining: 67%
The estimate for compound 3 lay 3 percentage points above the measured number; the range from low to high includes it.
By their numbers in this assay, from the lowest: compound 2; then compounds 3 and 1 (each within the scatter of the next).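

In this assay the aromatic carbon ortho to a 1H-pyrazol-4-yl group proves sensitive to which two-heavy-atom group it carries: cyano in place of ethyl gives a number 29 percentage points higher from compound 2 to compound 3 (beyond the scatter) on the shared core. Cyano in place of methyl gives a number 7 percentage points lower from compound 1 to compound 3 (within the scatter) and so cannot be told apart from methyl at this position, which leaves ethyl as the only one of the three groups set apart from the others. No measurement at hand accounts for this difference between the groups.

On these data alone, it remains open how a longer chain such as propyl, an amine or a carboxylic acid would read at this position. Also open, as far as these compounds go, is whether the match between cyano and methyl would hold if another part of the shared core were changed.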